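From Nitro to Fluoro on Compound 2

The source may report more compounds than this note shows. Statements on the series, on what has been measured and on what is new or still open speak of the compounds shown alone.

Measured so far in an ADME assay on L02 cells (Homo sapiens) for cytotoxicity, read by MTT assay, with a stated time of 24 h; a higher number here means a weaker inhibitor, a lower number a stronger inhibitor:
compound 1 `CN1C/C(=C\c2ccncc2)C(=O)/C(=C/c2ccccc2F)C1` gives 14900 nM
compound 2 `O=C1/C(=C/c2ccncc2)CN(S(=O)(=O)c2ccc([N+](=O)[O-])cc2)C/C1=C\c1ccccc1F` gives 18400 nM

Compound 2 at 18400 nM and compound 1 at 14900 nM lie within the usual scatter of each other, so these two numbers cannot be told apart. For the measured compounds named here, compound 2 therefore stands level with the only other measured compound.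

The next compound is compound 3 `O=C1/C(=C/c2ccncc2)CN(S(=O)(=O)c2ccc(F)cc2)C/C1=C\c1ccccc1F` and it differs from compound 2 in one place. The change fluoro in place of nitro on an aromatic carbon puts fluoro in place of nitro on an aromatic carbon, para to a large group, turning 4-nitrophenyl into 4-fluorophenyl.

Going by the values given here, no pair of measured compounds differs in just one place, so the data hold no direct precedent for this swap. Among the compounds with values here, the only guide is that compound 1 at 14900 nM and compound 2 at 18400 nM carry different groups on the shared core yet sit within the scatter. A step beyond the scatter is therefore not expected in this assay and no firm direction can be named. The expected step is a 1.2-fold lower number from compound 2 to compound 3 (0.06 log units; within the scatter) and it stays within the scatter. For compound 3 the estimated value is 16000 nM with a range from 8000 nM to 32000 nM expected.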

Compound 3, half-maximal inhibitory concentration: 15600 nM
Compound 3: the middle estimate sits 1.0-fold (0.01 log units) above what was measured; the range from low to high includes it.
By their numbers in this assay, from the lowest: compounds 1, 3 and 2 (each within the scatter of the next).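

In this assay, for the compounds shown here, the swap of 4-nitrophenyl to 4-fluorophenyl gives the first step at this position, a 1.2-fold lower number from compound 2 to compound 3 (0.07 log units; within the scatter), so here fluoro can stand in place of nitro on the aromatic carbon without a change that can be told from the scatter. The second step, a 1.0-fold higher number from compound 1 to compound 3 (0.02 log units; within the scatter), shows the same for a much larger exchange, with (4-fluorophenyl)sulfonyl in place of methyl on the amine nitrogen in the ring, and so gives a direct comparison that the first two compounds alone could not provide. No measurement is available to explain why neither change moves the number beyond the scatter.

The compounds shown leave open whether any group at this aromatic carbon, such as an amine or a carboxylic acid, would give a number beyond the scatter of these values. They also leave open whether a longer chain on the amine nitrogen, in place of methyl or the sulfonyl groups, would do so in this assay.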